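This account rests on a few compounds, and the source may have more. Where it says the series, first, only, none or still open, it means among the compounds named here.

Compound 3 `CC(=O)N1CC2CNCC2C1` carries an acetyl group on the shared core. Among the measured compounds shown here, in an assay on SHEP1 cells for displacement of a labelled ligand from Neuronal acetylcholine receptor; alpha4/beta2 (Homo sapiens), read by scintillation counting, with a stated time of 2 h (on this read-out higher numbers stand for weaker inhibition and lower numbers for stronger inhibition), compound 3 gives 38 nM, the second highest of the three numbers measured so far. Compound 2 `C[C@H]1C[C@@H]1C(=O)N1CC2CNCC2C1` gives 43 nM in this assay, and a 1.1-fold lower number from compound 2 to compound 3 (0.05 log units; within the scatter). Compound 1 `C[C@@H]1C[C@@H]1C(=O)N1CC2CNCC2C1` gives 1 nM in this assay; a 38-fold higher number from compound 1 to compound 3 (1.58 log units; beyond the scatter), and a 43-fold higher number from compound 1 to compound 2 (1.63 log units; beyond the scatter).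

Compound 4 `CCC(=O)N1CC2CNCC2C1` is not yet measured. It differs from compound 3 by methyl in place of hydrogen on a saturated chain carbon bound to a carbonyl carbon. For the measured compounds named here, no measured step adds a methyl at this place. Going by the values given here, the nearest comparison, methyl in place of 2-methylcyclopropyl on the carbonyl carbon, gave a 1.1-fold lower number from compound 2 to compound 3 (0.05 log units; within the scatter), while only the one arrangement found in compound 1 gave a large step, a 38-fold higher number from compound 1 to compound 3 (1.58 log units; beyond the scatter). Lengthening acetyl to propanoyl is a smaller change than either of these, so no step beyond the scatter is expected in this assay. The number for compound 4 is estimated at 30 nM, with a range of 8 nM to 110 nM, which means an expected step of a 1.3-fold lower number from compound 3 to compound 4 (0.10 log units; within the scatter).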

Compound 4, inhibition constant: 12 nM
Compound 4: the middle estimate sits 2.5-fold (0.40 log units) above what was measured; measured number inside the range.
By their numbers in this assay, from the lowest: compound 1; then compound 4; then compounds 3 and 2 (each within the scatter of the next).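

Chain length on the carbonyl carbon registers in this assay: methyl in place of hydrogen on the saturated chain carbon, acetyl to propanoyl, moves the number beyond the scatter (a 3.2-fold lower number from compound 3 to compound 4 (0.50 log units; beyond the scatter)). A difference at this place therefore does not depend on the arrangement found in compound 1, since ethyl also separates from the 2-methylcyclopropyl of compound 2 (a 3.6-fold lower number from compound 2 to compound 4 (0.55 log units; beyond the scatter)), while the 2-methylcyclopropyl of compound 1 still holds a large margin over ethyl (a 12-fold higher number from compound 1 to compound 4 (1.08 log units; beyond the scatter)). Nothing available gives a cause for the step from acetyl to propanoyl.

On these data alone, whether a longer chain such as butanoyl, or a branched one such as isobutyryl, would continue this trend stays open. So does the place of an unsubstituted cyclopropyl on the carbonyl carbon relative to ethyl and to the two 2-methylcyclopropyl forms.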